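Moving the Bromine Within the Furan Ring

The source may report more compounds than this note shows. Statements on the series, on what has been measured and on what is new or still open speak of the compounds shown alone.

Compound 1, `COc1ccc(CNC(=O)/C(C#N)=C/c2ccc(C)o2)cc1`: 58000 nM
Compound 2, `COc1ccc(CNC(=O)/C(C#N)=C/c2ccc(Br)o2)cc1`: 9000 nM

Among the compounds with values here, in a functional assay on A-431 cells (Homo sapiens) for inhibition, read by MTT assay, with a stated time of 72 h (on this read-out higher numbers stand for weaker inhibition of growth and lower numbers for stronger inhibition of growth), compound 2 gives 9000 nM, the lowest of the two numbers so far; compound 1 gives 58000 nM. Within the data shown here, the only measured step, a 6.4-fold lower number from compound 1 to compound 2 (0.81 log units; beyond the scatter), exchanged one group for another at the same spot on the furan.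

Compound 3, `COc1ccc(CNC(=O)/C(C#N)=C/c2cc(Br)co2)cc1`, differs from compound 2 in one place: 4-bromofuran-2-yl in place of 5-bromofuran-2-yl on a double-bonded chain carbon bound to a double-bonded chain carbon. Among the measured compounds shown here, no measured step bears directly on this change, since the step from compound 1 to compound 2 kept the position fixed and varied the group, whereas here the group is kept and its position moves. The data therefore give no basis for a confident direction. With the bromine no longer where compound 2 gained its advantage, a partial return toward compound 1 is plausible but uncertain.

Compound 3 is expected to give 20000 nM, within a wide range of 5000 nM to 70000 nM. That estimate means an expected step of a 2.2-fold higher number from compound 2 to compound 3 (0.35 log units; beyond the scatter).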

Compound 3, concentration for 50% growth inhibition: 14000 nM
For compound 3 the middle estimate is 1.4-fold (0.15 log units) above the measured one, and the stated range covers the measured number.
By their numbers in this assay, from the lowest: compounds 2 and 3 (each within the scatter of the next); then compound 1.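

Moving the bromine gives a 1.6-fold higher number from compound 2 to compound 3 (0.19 log units; within the scatter) in this assay, so 4-bromofuran-2-yl and 5-bromofuran-2-yl cannot be told apart on this read-out. The other comparison shows a 4.1-fold lower number from compound 1 to compound 3 (0.62 log units; beyond the scatter) and remains beyond the scatter, so the advantage over the methyl compound does not require the bromine to sit exactly where it does in compound 2. Nothing available here explains this result.

These three compounds cannot show whether bromine itself matters or whether another group on the furan would serve as well, such as a chloro group, an amine or a carboxylic acid. They also leave open whether the methyl of compound 1 would give a similar number if moved in the same way.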